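Series notes: hydroxymethyl for ethoxycarbonyl in compound 4

The source may report more compounds than this note shows. Statements on the series, on what has been measured and on what is new or still open speak of the compounds shown alone.

Measured so far:
compound 1 `CCOC(=O)[C@]1(C(=O)Nc2ccccc2)C[C@H]1c1cc(OC)c(OC)c(OC)c1` — 37300 nM
compound 2 `CCOC(=O)[C@]1(C(=O)NCc2ccc(C)cc2)C[C@H]1c1cc(OC)c(OC)c(OC)c1` — 13300 nM
compound 3 `CCOC(=O)[C@]1(C(=O)Nc2ccccc2)C[C@@H]1c1cc(OC)c(OC)c(OC)c1` — 21300 nM

In a functional assay on A549 cells (Homo sapiens) for cytotoxicity, read by MTT assay, with a stated time of 48 h (on this read-out higher numbers stand for weaker inhibition and lower numbers for stronger inhibition), compound 1 stands at the highest of the three numbers. Its nearest neighbour is compound 3, reached by a 1.8-fold lower number from compound 1 to compound 3 (0.24 log units; within the scatter); the two share every atom and bond, and the small gap sits with the fact that compounds 1 and 3 differ only in the configuration as drawn. The larger move is a 2.8-fold lower number from compound 1 to compound 2 (0.45 log units; beyond the scatter), which concerns the group on the amide-type nitrogen only.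

The unmeasured compound 4 `COc1cc([C@@H]2C[C@]2(CO)C(=O)Nc2ccccc2)cc(OC)c1OC` differs from compound 1 at the three-membered ring: hydroxymethyl in place of ethoxycarbonyl on a saturated ring carbon. Neither measured step touches this position. The step from compound 1 to compound 2 changes the amide side, and the step from compound 1 to compound 3 changes configuration alone, so neither gives a size or direction for the exchange of the ester for the alcohol. Going by the values given here, with no bearing step, the expectation for compound 4 is no shift beyond the scatter of this assay, and the expected step is a 1.1-fold higher number from compound 1 to compound 4 (0.03 log units; within the scatter). Compound 4 is therefore estimated at 40000 nM, with a range from 13000 nM to 120000 nM.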

Compound 4, half-maximal inhibitory concentration: 24100 nM
The estimate for compound 4 lay 1.7-fold (0.22 log units) above the measured number; low and high end bracket the measured number.
By their numbers in this assay, from the lowest: compounds 2, 3, 4 and 1 (each within the scatter of the next, the first and the last beyond it).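

In this assay, going by these compounds alone, the exchange of ethoxycarbonyl for hydroxymethyl on a saturated ring carbon gives a 1.5-fold lower number from compound 1 to compound 4 (0.19 log units; within the scatter), the first reading at this position, which neither the amide-side step nor the configuration step reached. The position thus takes a group of 2 heavy atoms in place of one of 5, and gains 1 hydrogen-bond donor, without a shift that this assay can resolve, so on this single pair the ester is not needed to hold the number at the level of compound 1. No measured property on hand bears on this step.

Open, going by these compounds, is whether the same position accepts a carboxylic acid, an aminomethyl group or a longer alkoxycarbonyl chain, and whether hydroxymethyl reads the same alongside the 4-methylbenzyl group on the amide-type nitrogen or in the other drawn configuration at the ring carbon. Such pairs would show whether the flat reading holds across the position or whether some group here moves the number beyond the scatter.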